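Replacing ((trifluoromethyl)carbonyl)amino on the shared core

This account rests on a few compounds, and the source may have more. Where it says the series, first, only, none or still open, it means among the compounds named here.

Of the compounds shown here, three sharing one core have been tested in a functional assay on MCF7 cells (Homo sapiens) for antiproliferative activity (a higher number here means a weaker inhibitor, a lower number a stronger inhibitor), and none has yet given a number. Compound 1 `CC(=O)N(C(C)=O)c1ccc(-c2nc3ccccc3s2)cc1`, carrying diacetylamino, gives > 100 nM, which is a limit. Compound 2 `O=C(CCl)Nc1ccc(-c2nc3ccccc3s2)cc1`, carrying ((chloromethyl)carbonyl)amino, gives > 10 nM, also a limit. Compound 3 `O=C(Nc1ccc(-c2nc3ccccc3s2)cc1)C(F)(F)F`, carrying ((trifluoromethyl)carbonyl)amino, gives > 10 nM, again a limit. Compound 3 therefore has no number of its own and stands at the limit of > 10 nM in this assay, at which 2 of the 3 values shown sit.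

The next structure is compound 4 `C/C(S)=N/c1ccc(-c2nc3ccccc3s2)cc1`, where the change on the aromatic carbon is a group of 4 heavy atoms (2 carbon, 1 nitrogen, 1 sulfur; no ring) in place of a group of 7 heavy atoms (2 carbon, 1 nitrogen, 1 oxygen, 3 fluorine; no ring), on an aromatic carbon. Going by the values given here, three measured steps bear on this position: a step that the two limits leave unreadable from compound 1 to compound 2, a step that the two limits leave unreadable from compound 1 to compound 3 and a step that the two limits leave unreadable from compound 2 to compound 3. Among the compounds with values here, none of them has a readable size or direction, and no measured compound carries the entering group. With no measured size to carry over, no step beyond the scatter is expected in this assay, and the expectation is a weak one. The estimated change is a step that the limit leaves unreadable from compound 3 to compound 4. For compound 4 the expected value is 30 nM, with an estimated range of 8 nM to 300 nM.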

Compound 4, half-maximal inhibitory concentration: > 100 nM
Compound 4 was reported as a limit (the forecaster's own chance of this, stated with the estimate: 60%); at least 3.3-fold (0.52 log units) between middle value and limit.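

In this assay compound 4 gives > 100 nM as a limit. Compound 1, compound 2, compound 3 and compound 4 all stand as limits, and the steps to compound 4 from the other three cannot be read. The compounds shown leave open whether in this assay any group at this position on the shared core gives an actual number.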